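Swapping chloro for ethyl in compound 3

The source may report more compounds than this note shows. Statements on the series, on what has been measured and on what is new or still open speak of the compounds shown alone.

Values measured in a functional assay on the whole organism for inhibition, with Rattus norvegicus as the target; a higher number here means that more compound is needed for the effect, a lower number that less compound is needed:
Compound 1 `CCc1ccc(CC(C)(Oc2ccc(C(C)C)cc2)C(=O)O)cc1`: 0.1 mg/kg
Compound 2 `CC(Cc1ccc(Cl)cc1)(Oc1ccc(C2CCSc3ccccc32)cc1)C(=O)O`: 10 mg/kg
Compound 3 `CC(Cc1ccc(Cl)cc1)(Oc1ccc(Oc2ccccc2)cc1)C(=O)O`: < 1 mg/kg (a limit, not a number)

Compound 3 reads < 1 mg/kg in this assay, and this is a limit of the assay, not a number. From the compounds shown here alone, its exact place on the dose scale therefore remains open.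

Compound 4 `CCc1ccc(CC(C)(Oc2ccc(Oc3ccccc3)cc2)C(=O)O)cc1` keeps all of compound 3 except one group: ethyl in place of chloro on an aromatic carbon, (ethyl in place of chloro on an aromatic carbon). Within the data shown here, the only measured step, an at least 10-fold lower number from compound 2 to compound 3 (1.00 log units; beyond the scatter), concerns a different group, so its size says nothing direct about this swap. Among the measured compounds shown here, no measured pair isolates chloro against ethyl.

The nearest guide is compound 1, which carries the same 4-ethylbenzyl group and gives 0.1 mg/kg, although it differs from compound 4 in its other large group. That low dose suggests that the ethyl group is compatible with a small required dose, so a modest move towards a lower number in this assay is expected, with little certainty. The expected change is a step that the limit leaves unreadable from compound 3 to compound 4. For compound 4 the estimated dose is 0.3 mg/kg. The expected range runs from 0.05 mg/kg to 2 mg/kg.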

Compound 4, dose for half-maximal effect: 1 mg/kg
Beside the measured number, compound 4's estimate is 3.3-fold (0.52 log units) below it, within the range that was stated.
By their numbers in this assay, from the lowest: compound 1; then compound 4; then compound 2.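

In this assay, ethyl in place of chloro on an aromatic carbon gives a number no lower from compound 3 to compound 4 (the limit leaves the size open). With the 4-ethylbenzyl group held fixed, compound 1 and compound 4 differ in one place, and this gives a direct reading of phenoxy against isopropyl. In this assay, phenoxy in place of isopropyl on an aromatic carbon gives a 10-fold higher number from compound 1 to compound 4 (1.00 log units; beyond the scatter), a change beyond the usual scatter. The low dose of compound 1 therefore does not come with the 4-ethylbenzyl group alone, since the same group gives a clearly higher number when phenoxy is present. The step from chloro to ethyl itself cannot be read, because compound 3 is known only through a limit: the limit of < 1 mg/kg in this assay, at which 1 of the 4 values shown sits.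

From the compounds shown here alone, it remains open whether chloro and ethyl differ at all in this position, and whether the difference between phenoxy and isopropyl would be the same with chloro in place of ethyl. The compounds shown also do not tell how a methoxy group, an amine or a longer chain such as butyl would compare with ethyl on this aromatic carbon.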